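Swapping the Amide-Nitrogen Substituent in a Glucagon Receptor Series

This account rests on a few compounds, and the source may have more. Where it says the series, first, only, none or still open, it means among the compounds named here.

Compound 1 `O=C(O)CCNC(=O)c1ccc(CN(C(=O)Nc2ccc(OC(F)(F)F)cc2)C2CCC(C(=O)O)CC2)cc1`: > 10000 nM
Compound 2 `O=C(O)CCNC(=O)c1ccc(CN(C(=O)Nc2ccc(OC(F)(F)F)cc2)C2CCN(C(=O)C3CC3)CC2)cc1`: 1980 nM

In an in vitro assay on BHK cells for inhibition of Glucagon receptor (Homo sapiens) (on this read-out higher numbers stand for weaker inhibition and lower numbers for stronger inhibition), compound 1 gives only a limit, > 10000 nM. Compound 2 gives the sole number shown, 1980 nM. For the measured compounds named here, the step of an at least 5.0-fold lower number from compound 1 to compound 2 (0.70 log units; beyond the scatter) is the only measured step; it rests on the limit (the limit of > 10000 nM in this assay, at which 1 of the 2 values shown sits). Compound 3 `CC(C)C1CCC(N(Cc2ccc(C(=O)NCCC(=O)O)cc2)C(=O)Nc2ccc(OC(F)(F)F)cc2)CC1` differs from compound 2 by 4-isopropylcyclohexyl in place of 1-(cyclopropylcarbonyl)piperidin-4-yl on an amide-type nitrogen. Going by the values given here, no measured step bears directly on this change. Compound 3 is therefore expected to give about 1200 nM, with a range from 250 nM to 6000 nM, meaning an estimated step of a 1.7-fold lower number from compound 2 to compound 3 (0.22 log units; within the scatter) that may well stay within the scatter.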

Compound 3, half-maximal inhibitory concentration: 59 nM
Compound 3: the middle estimate sits 20-fold (1.31 log units) above what was measured; the measured number lies below the stated range.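

At this amide-type nitrogen, 4-isopropylcyclohexyl gives the lowest number of the three compounds: in this assay, replacing 1-(cyclopropylcarbonyl)piperidin-4-yl brings a 34-fold lower number from compound 2 to compound 3 (1.53 log units; beyond the scatter), far beyond what the earlier step showed. On the saturated ring carbon, isopropyl in place of carboxy brings an at least 160-fold lower number from compound 1 to compound 3 (2.22 log units; beyond the scatter), so a purely carbon substituent can outperform both earlier groups. That second step rests on compound 1, whose value is a limit: the limit of > 10000 nM in this assay, at which 1 of the 3 values shown sits.

The compounds shown leave open whether the isopropyl group itself is needed, or whether a methyl or tert-butyl group on the cyclohexyl ring would serve as well. They also leave open how a hydroxyl or an amine at that ring carbon would compare.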